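Chlorobenzyl placement on the shared core: cytotoxicity notes

The source may report more compounds than this note shows. Statements on the series, on what has been measured and on what is new or still open speak of the compounds shown alone.

Compound 2 `O=C1c2ccccc2N(Cc2ccccc2)S(=O)(=O)N1Cc1ccc(Cl)cc1` holds the lower of the two numbers recorded in a functional assay on HEL cells (Homo sapiens); on this read-out lower numbers stand for higher toxicity in this test and higher numbers for lower toxicity in this test; in that test compound 2 gives 20000 nM. The nearest neighbour is compound 3 `O=C(OCOCN1c2ccccc2C(=O)N(Cc2ccccc2)S1(=O)=O)c1ccccc1`, which in this assay gives 110000 nM, a gap that lies beyond the scatter of repeated runs. Compound 1 `O=C1c2ccccc2N(Cc2ccccc2Cl)S(=O)(=O)N1Cc1ccccc1Cl` reaches only a limit: in this assay compound 1 gives > 20000 nM, which is a limit of the test and not a number, as noted in the limit of > 20000 nM in this assay, at which 1 of the 3 values shown sits. Among the compounds with values here, no pair of measured compounds differs in a single place, so no measured step can be quoted for this series.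

Compound 4 `O=C1c2ccccc2N(Cc2ccccc2)S(=O)(=O)N1Cc1ccccc1Cl` remains to be measured. It differs from compound 2 as follows: 2-chlorophenyl in place of 4-chlorophenyl on a saturated chain carbon bound to an amide-type nitrogen in a ring. Compound 1 also carries the 2-chlorobenzyl group, and in this assay compound 1 gives > 20000 nM, a limit. The expected step is therefore a 1.3-fold higher number from compound 2 to compound 4 (0.10 log units; within the scatter), which stays within the scatter and, if anything, points toward a higher number. For compound 4 the estimate in this assay is 25000 nM, with a range from 10000 nM to 60000 nM, and a fair chance that the test again reports only a limit.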

Compound 4, minimum cytotoxic concentration: 200000 nM
Estimate against measurement, compound 4: 8.0-fold (0.90 log units) below, and the stated range ends below it.
By their numbers in this assay, from the lowest: compound 2; then compounds 3 and 4 (each within the scatter of the next).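

Within the data shown here, the swap of 2-chlorophenyl in place of 4-chlorophenyl, on a saturated chain carbon bound to an amide-type nitrogen in a ring, gives the first readable step in this assay: a 10-fold higher number from compound 2 to compound 4 (1.00 log units; beyond the scatter). The two compounds hold the same atoms, joined differently, so this step reflects the placement of the chlorine on the phenyl ring alone, and this place in the shared core responds to that placement, with the 2-chlorobenzyl compound giving the higher number and so the lower toxicity in this test. Compound 1, which also carries the 2-chlorobenzyl group, gives > 20000 nM in this assay, a limit and not a number, so its step, hydrogen in place of chloro on an aromatic carbon, cannot be read: the limit of > 20000 nM in this assay, at which 1 of the 4 values shown sits.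

The compounds shown leave open whether the step belongs to chloro itself or would also appear with bromo or methoxy on the same phenyl ring. They also leave open whether it survives a longer chain between the phenyl ring and the ring nitrogen, or an amine on that chain.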